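Swapping the Sulfur-Bound Ring in a Hydrazone Series

The source may report more compounds than this note shows. Statements on the series, on what has been measured and on what is new or still open speak of the compounds shown alone.

Compound 1 `C/C(=N\NC(=O)c1ccc(CSc2nc3ccccc3s2)cc1)c1ccc(C)c([N+](=O)[O-])c1`: > 80 ug/mL
Compound 2 `C/C(=N\NC(=O)c1ccc(CSc2nc3ccccc3s2)cc1)c1ccc([N+](=O)[O-])cc1`: 35.7 ug/mL

Both compounds were tested in a functional assay on HepG2 cells (Homo sapiens) for inhibition, read by MTT assay, with a stated time of 72 h; a higher number here means a weaker inhibitor, a lower number a stronger inhibitor. For compound 1 the result > 80 ug/mL is a limit of this assay, not a number. Compound 2 differs from compound 1 only on the carbon with a double bond to nitrogen, and there an at least 2.2-fold lower number from compound 1 to compound 2 (0.35 log units; beyond the scatter). So compound 1 stands at the weak end of what has been measured, and the one known step leads away from it, towards a stronger inhibitor, through a change elsewhere in the molecule.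

Compound 3 `C/C(=N\NC(=O)c1ccc(CSc2nc(C)cc(C)n2)cc1)c1ccc(C)c([N+](=O)[O-])c1` keeps the hydrazone side of compound 1 unchanged and alters only the ring on the sulfur: 4,6-dimethylpyrimidin-2-yl in place of 1,3-benzothiazol-2-yl on a sulfur. Among the measured compounds shown here, no measured step touches this position, so the step from compound 1 to compound 2 gives no guide to its direction or size. With compound 1 at the limit of > 80 ug/mL in this assay, at which 1 of the 2 values shown sits, the expectation for compound 3 is that it stays near that limit, so a number no higher from compound 1 to compound 3 (the limit leaves the size open) is expected to be no change beyond the scatter. Compound 3 is estimated at 80 ug/mL, in the range 30 ug/mL to 200 ug/mL.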

Compound 3, half-maximal inhibitory concentration: > 80 ug/mL
Compound 3: a limit, no number; the forecaster's own chance of this, stated with the estimate: 60%; the middle value sits exactly at the limit.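

In this assay compound 3 gives > 80 ug/mL, which is a limit of the assay and not a number. Among the compounds shown here, compound 1 also rests on a limit, so no step from compound 1 to compound 3 can be read. The compounds shown leave open whether swapping 1,3-benzothiazol-2-yl for 4,6-dimethylpyrimidin-2-yl on the sulfur changes inhibition at all.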